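A few compounds are considered here, and "the series" means these few. Any claim that something is new, unique, unknown or untested is made for them only; others in the source may bear on it.

Working notes on the series. Compound 1 `CC(Oc1ccc(Oc2ccc(C(F)(F)F)cc2)cc1)C(=O)Cn1nnc(-c2ccccc2)n1` gives 6% in an ADME assay on S9 fraction from liver (Rattus norvegicus) for metabolic stability, read by LC-MS, using NADPH, with a stated time of 30 min; on this read-out higher numbers stand for a more stable compound and lower numbers for a less stable compound. Compound 2 `CC(Oc1ccc(-c2ccccc2)cc1)C(=O)Cn1nnc(-c2ccccc2)n1` is reported in this assay only at the limit of < 5%, a limit of the measurement (the limit of < 5% in this assay, at which 1 of the 3 values shown sits). The step of a number at least 1 percentage points lower from compound 1 to compound 2 (that floor lies within the scatter) follows the change (phenyl in place of 4-(trifluoromethyl)phenoxy on an aromatic carbon). Compound 3 `CC(Oc1ccc(Oc2ccc(C(F)(F)F)cc2)cc1)C(=O)Cn1nnc(-c2ccc(Cl)cc2)n1` gives 9% in this assay, with the step of a number 3 percentage points higher from compound 1 to compound 3 (within the scatter) resting on (chloro in place of hydrogen on an aromatic carbon). Compound 4 `CC(Oc1ccc(-c2ccccc2)cc1)C(=O)Cn1nnc(-c2ccc(Cl)cc2)n1` is not yet measured; it differs from compound 3 by phenyl in place of 4-(trifluoromethyl)phenoxy on an aromatic carbon, the same change as that from compound 1 to compound 2, and its core differs from the core of compound 1 by chloro in place of hydrogen on an aromatic carbon. Compound 4 is expected to show the step of a number 4 percentage points lower from compound 3 to compound 4 (within the scatter), resting on compound 3 at 9% and on the earlier step of a number at least 1 percentage points lower from compound 1 to compound 2 (that floor lies within the scatter). Compound 4 is therefore estimated at 5%, between 2% and 10%.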

Compound 4, percent of the compound remaining: 18%
Estimate against measurement, compound 4: 13 percentage points below, and the stated range ends below it.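

In this assay, phenyl in place of 4-(trifluoromethyl)phenoxy gives a number 9 percentage points higher from compound 3 to compound 4 (within the scatter), and this sits beside the earlier step on the other core as follows: the same change on two cores in this assay, a number at least 1 percentage points lower (that floor lies within the scatter) from compound 1 to compound 2 and a number 9 percentage points higher (within the scatter) from compound 3 to compound 4; the limit leaves it open whether they differ

Chloro in place of hydrogen gives a number at least 13 percentage points higher from compound 2 to compound 4 (beyond the scatter), the only step here beyond the scatter, but this does not show that the change carries the same size from one core to the other: the same change on two cores in this assay, a number 3 percentage points higher (within the scatter) from compound 1 to compound 3 and a number at least 13 percentage points higher (beyond the scatter) from compound 2 to compound 4; the limit leaves it open whether they differ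

Compound 2 is reported only at a limit, so neither change can be said to carry over or to fail to carry over: the limit of < 5% in this assay, at which 1 of the 4 values shown sits.

The compounds shown leave open how either change behaves when all four values of a set lie clear of the limit. They also leave open what an amine or a carboxylic acid in place of the chloro would give in this assay.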